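Swapping an Ether Arm for Isobutyl on a Sulfonamide

A few compounds are considered here, and "the series" means these few. Any claim that something is new, unique, unknown or untested is made for them only; others in the source may bear on it.

Compound 1 `COCCN(C)S(=O)(=O)c1ccc(C)c(C#Cc2cc(Cl)ccc2OCC(=O)O)c1` was tested in an assay on CHO cells for displacement of a labelled ligand from prostaglandin D2 receptor 2 (Homo sapiens), read by scintillation counting (on this read-out higher numbers stand for weaker inhibition and lower numbers for stronger inhibition), where compound 1 gives 4.1 nM. Compound 2 `O=C(O)COc1ccc(Cl)cc1C#Cc1ccccc1C(F)(F)F` gives 24 nM in this assay. Of these two numbers, compound 1 has the lower one, and its gap to compound 2 lies beyond the scatter. Compound 3 `Cc1ccc(S(=O)(=O)N(C)CC(C)C)cc1C#Cc1cc(Cl)ccc1OCC(=O)O` has not yet been measured. It differs from compound 1 in one place: isopropyl in place of methoxymethyl on a saturated chain carbon bound to a sulfonamide nitrogen. Among the compounds with values here, no measured pair shows this change, so there is no step to lean on. The step expected in this assay is a 1.5-fold higher number from compound 1 to compound 3 (0.17 log units; within the scatter), a shift of no more than the scatter, in either direction. Compound 3 is therefore estimated at 6 nM, with a range from 2 nM to 20 nM.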

Compound 3, inhibition constant: 4.2 nM
Estimate against measurement, compound 3: 1.4-fold (0.15 log units) above; low and high end bracket the measured number.
By their numbers in this assay, from the lowest: compounds 1 and 3 (each within the scatter of the next); then compound 2.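

In this assay, methoxymethyl gives way to isopropyl on a saturated chain carbon bound to a sulfonamide nitrogen, with a 1.0-fold higher number from compound 1 to compound 3 (0.01 log units; within the scatter). Within the data shown here, at this place, then, the arm with an ether oxygen and its hydrogen-bond acceptor and the all-carbon arm read alike, something the earlier compounds could not show. Nothing on hand explains this result. Still open, from the compounds shown here alone, is how far this place tolerates other groups: an amine or a carboxylic acid on the chain, a longer chain, or a ring in place of the isobutyl.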